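From Dichlorophenyl to Bare Phenyl on the Chain

The compounds below may be only part of what the source reports. "The series", "measured", "known", "first", "only" and "open" are said of these compounds alone.

Compound 1, `CCCc1cc(N)c2cc(NC(=O)/C=C/c3ccc(I)cc3)ccc2n1`: 2.3 nM
Compound 2, `CCCc1cc(N)c2cc(NC(=O)/C=C/c3ccc(Cl)c(Cl)c3)ccc2n1`: 60 nM

Within the data shown here, in an assay on isolated protein for displacement of a labelled ligand from melanin-concentrating hormone receptor 1 (Homo sapiens) (a higher number here means a weaker inhibitor, a lower number a stronger inhibitor), compound 2 gives 60 nM, the highest of the two numbers measured so far. Among the measured compounds shown here, the nearest is compound 1 at 2.3 nM, and the one step between them, a 26-fold higher number from compound 1 to compound 2 (1.42 log units; beyond the scatter), shows that swapping the substituents on the phenyl ring at the end of the double-bonded chain moves this assay strongly.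

Compound 3, `CCCc1cc(N)c2cc(NC(=O)/C=C/c3ccccc3)ccc2n1`, takes the change one step further: phenyl in place of 3,4-dichlorophenyl on a double-bonded chain carbon bound to a double-bonded chain carbon. For the measured compounds named here, no measured pair shows the removal of both chlorines, so the only guidance is that the ring's substitution pattern matters a great deal, seen in a 26-fold higher number from compound 1 to compound 2 (1.42 log units; beyond the scatter). Which way a bare ring shifts the number cannot be read from two compounds; the expectation is a step of uncertain direction, likely smaller than the one measured, with a slight lean toward a weaker inhibitor.

The estimate for compound 3 in this assay is 110 nM, with a range from 20 nM to 600 nM. That estimate corresponds to an expected step of a 1.8-fold higher number from compound 2 to compound 3 (0.26 log units; within the scatter).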

Compound 3, half-maximal inhibitory concentration: 1000 nM
Compound 3: middle estimate off by 9.1-fold (0.96 log units), on the low side, and the stated range ends below it.
By their numbers in this assay, from the lowest: compound 1; then compound 2; then compound 3.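

The bare phenyl ring is the weakest of the three in this assay, which the first two compounds could not show, since both of them carry halogens on this ring. Removing the substituents raises the number sharply from either starting point, with a 17-fold higher number from compound 2 to compound 3 (1.22 log units; beyond the scatter) and a 430-fold higher number from compound 1 to compound 3 (2.64 log units; beyond the scatter), so at this place on the double-bonded chain carbon the ring substituents account for a very large part of the inhibition seen in this series of three. Taking away the iodo group moves the number much further than taking away both chlorines, but nothing available here explains why these groups matter so much.

From the compounds shown here alone, it remains open whether halogens are specifically needed or whether other groups on this ring, such as methyl, methoxy or trifluoromethyl, would also restore strong inhibition. It is also unclear how a ring carrying a single chlorine or a bromine would compare, or whether a ring bearing an amine or a carboxylic acid would be tolerated at all.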